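This account rests on a few compounds, and the source may have more. Where it says the series, first, only, none or still open, it means among the compounds named here.

Three ureas sharing one core have been measured in an assay on HeLa cells for inhibition of Indoleamine 2,3-dioxygenase 1 (Homo sapiens), with stated times of 1 h and 18 h; a higher number here means a weaker inhibitor, a lower number a stronger inhibitor. Compound 1 `Cc1ccc(NC(=O)Nc2cc(-c3ccccc3C(=O)O)ccc2Oc2ccccc2C(C)(C)C)cc1` gives 70 nM, compound 2 `Cc1ccc(NC(=O)Nc2cc(-c3ccccc3C(=O)O)ccc2Nc2ccccc2C(C)(C)C)cc1` gives 600 nM, and compound 3 `CCN(c1ccc(-c2ccccc2C(=O)O)cc1NC(=O)Nc1ccc(C)cc1)C1CCCC1` gives 23 nM. Compound 2 therefore holds the highest of the three numbers: the nearest to it is compound 1, with an 8.6-fold higher number from compound 1 to compound 2 (0.93 log units; beyond the scatter) separating them, and the furthest is compound 3, reached through a 26-fold lower number from compound 2 to compound 3 (1.42 log units; beyond the scatter).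

Compound 4 `Cc1ccc(NC(=O)Nc2cc(-c3ccccc3C(=O)O)ccc2N(CC(C)C)CC(C)C)cc1` is the next member of this set and has not yet been measured. Compared with compound 2, the change is diisobutylamino in place of (2-(tert-butyl)phenyl)amino on an aromatic carbon. Two of the measured steps bear on this move. The first, a 26-fold lower number from compound 2 to compound 3 (1.42 log units; beyond the scatter), replaces the same (2-(tert-butyl)phenyl)amino group with a dialkylamino group lacking any ring, and the number falls sharply. The second, a 3.0-fold lower number from compound 1 to compound 3 (0.48 log units; beyond the scatter), shows that the ring-free amino group also gives a lower number than the ether of compound 1. Diisobutylamino, like cyclopentyl(ethyl)amino, carries no ring and no hydrogen-bond donor, so a large fall in this assay is expected, of roughly a 15-fold lower number from compound 2 to compound 4 (1.18 log units; beyond the scatter), since compound 3 reached 23 nM. Compound 4 is accordingly estimated at 40 nM in this assay, with a range from 12 nM to 130 nM.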

Compound 4, half-maximal inhibitory concentration: 13 nM
Estimate against measurement, compound 4: 3.1-fold (0.49 log units) above; measured number inside the range.
By their numbers in this assay, from the lowest: compounds 4 and 3 (each within the scatter of the next); then compound 1; then compound 2.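

In this assay, the step to a second ring-free dialkylamino group, a 46-fold lower number from compound 2 to compound 4 (1.66 log units; beyond the scatter), shows that the large fall seen with compound 3 is not unique to cyclopentyl(ethyl)amino, as it recurs with diisobutylamino at this place ortho to the ((4-methylphenyl)carbamoyl)amino group. The two dialkylamino groups are not separated by the measurement, with a 1.8-fold lower number from compound 3 to compound 4 (0.25 log units; within the scatter), so this position tolerates the exchange of one for the other without a readable change in the number. The comparison with the ether, a 5.4-fold lower number from compound 1 to compound 4 (0.73 log units; beyond the scatter), gives a second case of a ring-free dialkylamino group lying beyond the scatter of the 2-(tert-butyl)phenoxy compound.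

Nothing measured here accounts for these differences. The step from compound 2 to compound 4 removes the aromatic ring and the hydrogen-bond donor together, so the effect of each remains unresolved, and a methyl(phenyl)amino group, which has the ring but no amine hydrogen, or a smaller dimethylamino group would be needed to show which change matters and how much alkyl bulk this position requires.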